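The compounds below may be only part of what the source reports. "The series", "measured", "known", "first", "only" and "open" are said of these compounds alone.

Compound 1, `COc1ccc(/C=C/c2cc(OC)cc(OC)c2/C=C/C(=O)c2ccccc2)cc1`, carries an unsubstituted phenyl ketone; in a functional assay on A549 cells (Homo sapiens) for antiproliferative activity, read by MTT assay, with a stated time of 48 h (on this read-out lower numbers stand for stronger inhibition and higher numbers for weaker inhibition), compound 1 gives 3.9 ug/mL. Compound 2, `COc1ccc(/C=C/c2cc(OC)cc(OC)c2/C=C/C(=O)c2ccc(F)cc2)cc1`, has fluoro in place of hydrogen on an aromatic carbon, and in this assay compound 2 gives 6.6 ug/mL. Compound 3, `COc1ccc(/C=C/c2cc(OC)cc(OC)c2/C=C/C(=O)c2ccc(Cl)cc2)cc1`, has chloro at the same position, and in this assay compound 3 gives 6.4 ug/mL. On these numbers compound 3 stands second highest of the three, with compound 2 nearest and compound 1 furthest, and all three values lie within the scatter of one another: a 1.6-fold higher number from compound 1 to compound 3 (0.22 log units; within the scatter), a 1.0-fold lower number from compound 2 to compound 3 (0.01 log units; within the scatter).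

Compound 4, `CCN(CC)c1ccc(C(=O)/C=C/c2c(/C=C/c3ccc(OC)cc3)cc(OC)cc2OC)cc1`, differs from compound 3 in one place: diethylamino in place of chloro on an aromatic carbon, on an aromatic carbon of a six-membered aromatic ring of carbon only, para to a large group. Within the data shown here, no measured step covers a diethylamino group. Among the measured compounds shown here, the steps that bear on it are those at the same aromatic carbon, a 1.7-fold higher number from compound 1 to compound 2 (0.23 log units; within the scatter) and a 1.6-fold higher number from compound 1 to compound 3 (0.22 log units; within the scatter), both within the scatter, so substitution at this position has so far produced no step beyond the scatter. The expected step in this assay is therefore a 1.1-fold higher number from compound 3 to compound 4 (0.04 log units; within the scatter), at most a small rise. Compound 4 is estimated at 7 ug/mL, with a range from 3 ug/mL to 16 ug/mL.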

Compound 4, half-maximal inhibitory concentration: 5.4 ug/mL
Compound 4: the middle estimate sits 1.3-fold (0.11 log units) above what was measured, within the range that was stated.
By their numbers in this assay, from the lowest: compounds 1, 4, 3 and 2 (each within the scatter of the next).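

The earlier compounds had shown only single halogen atoms at this aromatic carbon, para to a large group, whereas diethylamino brings five heavy atoms, a nitrogen and a hydrogen-bond acceptor to the same place. Even so, this assay gives a 1.2-fold lower number from compound 3 to compound 4 (0.07 log units; within the scatter), a 1.2-fold lower number from compound 2 to compound 4 (0.09 log units; within the scatter) and a 1.4-fold higher number from compound 1 to compound 4 (0.14 log units; within the scatter), so this much larger replacement produces no step beyond the scatter against chloro, fluoro or hydrogen. Across these compounds, the number of heavy atoms at this position therefore shows no link with the read-out, but nothing measured here explains that absence.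

The compounds shown leave open whether a carboxylic acid, a primary amine or a longer alkyl chain on this same carbon would give a step beyond the scatter, since every group so far keeps the values within it. They also leave open how the read-out would respond if a methoxy group on the shared core were replaced by a hydroxyl group, since all of the changes shown lie on the phenyl ketone ring.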